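A few compounds are considered here, and "the series" means these few. Any claim that something is new, unique, unknown or untested is made for them only; others in the source may bear on it.

Series notes. In an assay on SH-SY5Y cells for inhibition of Voltage-dependent L-type calcium channel subunit alpha-1D (Homo sapiens), read by calcium flux, with a stated time of 15 min (on this read-out lower numbers stand for stronger inhibition and higher numbers for weaker inhibition), compound 1 `CCOC(=O)C1=C(C)NC(c2ccccc2)=CC1c1ccccc1` gives 18700 nM, compound 2 `CCOC(=O)C1=C(C)NC(c2ccc(Cl)cc2)=CC1c1ccccc1` gives 9300 nM, and compound 3 `C=CCOC(=O)C1=C(C)NC(c2ccc(Cl)cc2)=CC1c1ccccc1` gives 18500 nM. Compound 2 holds the lowest of the three numbers, but its steps to both neighbours stay within the scatter: from compound 1 to compound 2, a 2.0-fold lower number from compound 1 to compound 2 (0.30 log units; within the scatter), and from compound 2 to compound 3, a 2.0-fold higher number from compound 2 to compound 3 (0.30 log units; within the scatter). No order among the three can be claimed.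

Compound 4 `CCOC(=O)C1=C(C)NC(c2ccc(Cl)cc2)=CC1c1ccccc1[N+](=O)[O-]` differs from compound 2 by nitro in place of hydrogen on an aromatic carbon, placed on an aromatic carbon of a six-membered aromatic ring of carbon only, ortho to a large group. Neither measured step touches this ring: the chloro step sits on the other aromatic ring, the vinyl step on the ester chain, and both were within the scatter. Going by the values given here, the series therefore gives no step that bears directly on this change, and no step so far has moved this assay beyond the scatter.

The expectation for compound 4 in this assay is a value near compound 2, estimated at 7000 nM with a range of 2000 nM to 25000 nM. The expected step from compound 2 to compound 4 is a 1.3-fold lower number from compound 2 to compound 4 (0.12 log units; within the scatter).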

Compound 4, half-maximal inhibitory concentration: 57100 nM
For compound 4 the middle estimate is 8.2-fold (0.91 log units) below the measured one; the whole stated range lies below it.
By their numbers in this assay, from the lowest: compounds 2, 3 and 1 (each within the scatter of the next); then compound 4.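

In this assay, going by these compounds alone, the change from phenyl to 2-nitrophenyl gives a 6.1-fold higher number from compound 2 to compound 4 (0.79 log units; beyond the scatter) and is the only step that lies beyond the scatter, with the number moving towards weaker inhibition. Within the data shown here, this ring therefore tolerates less than the earlier steps suggested: the chloro and vinyl steps, both within the scatter and both made elsewhere on the molecule, gave no sign that a nitro group on an aromatic carbon, ortho to a large group, could shift the read-out this far. Nothing at hand gives a cause for this step.

As far as these compounds go, whether an amine, a methoxy group or a chloro in the same place would give a step of similar size stays open. It also stays open whether the step belongs to the nitro group as such or to this place on the ring, since the compounds shown carry nitro in one place only.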